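Swapping the aryl ester group toward a bromo-methylphenyl

The source may hold more compounds than are shown below. What is called first, only, known or untested is meant among the compounds shown, and "the series" means these compounds.

Compound 1 `COc1ccc(C(=O)OC(CCN(C)C)c2ccc(Cl)cc2)cc1`: 2190 nM
Compound 2 `Cc1ccsc1C(=O)OC(CCN(C)C)c1ccc(Cl)cc1`: 2510 nM
Compound 3 `Cc1cccc(C(=O)OC(CCN(C)C)c2ccc(Cl)cc2)c1C`: 1150 nM

Three esters sharing one core have been tested in an assay on NIH3T3 cells with Urotensin-2 receptor (Homo sapiens) as the target; on this read-out lower numbers stand for an effect already at smaller amounts and higher numbers for an effect only at larger amounts of compound. Compound 3 gives the lowest number of the three, but the step of a 1.9-fold lower number from compound 1 to compound 3 (0.28 log units; within the scatter) stays within the scatter, while the step of a 2.2-fold lower number from compound 2 to compound 3 (0.34 log units; beyond the scatter) is modest. Compound 4 `Cc1cc(Br)ccc1C(=O)OC(CCN(C)C)c1ccc(Cl)cc1` carries the change (4-bromo-2-methylphenyl in place of 2,3-dimethylphenyl on a carbonyl carbon). No measured step involves a halogen on this aryl group, so the expectation rests only on the three aryl swaps shown, all of which moved the number by little. The estimated step of a 1.3-fold higher number from compound 3 to compound 4 (0.12 log units; within the scatter) for compound 4 is therefore no step beyond the scatter, and compound 4 is expected to give about 1500 nM, within 600 nM to 3800 nM.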

Compound 4, half-maximal effective concentration: 1070 nM
Estimate against measurement, compound 4: 1.4-fold (0.15 log units) above, within the range that was stated.
By their numbers in this assay, from the lowest: compounds 4, 3, 1 and 2 (each within the scatter of the next, the first and the last beyond it).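

The step of a 1.1-fold lower number from compound 3 to compound 4 (0.03 log units; within the scatter) shows that a bromine-bearing aryl group, 4-bromo-2-methylphenyl, can replace 2,3-dimethylphenyl on this carbonyl carbon with no change beyond the scatter. Compound 4 is also the only ester here clear of the scatter from both others, through a 2.3-fold lower number from compound 2 to compound 4 (0.37 log units; beyond the scatter) and the modest step of a 2.0-fold lower number from compound 1 to compound 4 (0.31 log units; beyond the scatter) in this assay. Nothing available here explains these results. Still open, as far as these compounds go, is how this read-out would respond to an aryl group carrying an amine or a carboxylic acid, since all four esters keep closely similar uncharged aryl groups.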